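Series notes: ether side chain of the shared core

The source may hold more compounds than are shown below. What is called first, only, known or untested is meant among the compounds shown, and "the series" means these compounds.

Among the compounds with values here, compound 1 `Cc1nn(-c2ncnc3nc[nH]c23)c2c1C(OCc1ccccc1Cl)CC(=O)N2` is one of two compounds measured in a functional assay on HEK293 cells for agonist activity at G-protein coupled receptor 39 (Homo sapiens), read by scintillation proximity assay and inositol phosphate accumulation, with a stated time of 75 min, in the presence of a further agent that is not named here; on this read-out lower numbers stand for an effect already at smaller amounts and higher numbers for an effect only at larger amounts of compound. In this assay compound 1 gives 2 nM, the lowest of the two numbers. Within the data shown here, compound 2 `O=C1/C(=C/NCCCO)C(c2ccccc2)=NN1c1nc2ccccc2s1`, built on a different scaffold, gives 200 nM in this assay; the gap between the two values is beyond the scatter, and no step between them is counted.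

Compound 3 `Cc1nn(-c2ncnc3nc[nH]c23)c2c1C(OCCn1cccn1)CC(=O)N2` keeps the shared core of compound 1 and changes the ether side chain: (1H-pyrazol-1-yl)methyl in place of 2-chlorophenyl on a saturated chain carbon bound to an oxygen on a saturated carbon The change swaps a ring of carbon only for a smaller ring with two hetero atoms set one carbon further from the oxygen.

Among the measured compounds shown here, no measured pair shows this kind of change. The step of a 7.5-fold higher number from compound 1 to compound 3 (0.88 log units; beyond the scatter) is expected to run towards a higher number, moderate in size, beyond the scatter. Compound 3 is estimated at 15 nM, with a range from 3 nM to 80 nM.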

Compound 3, half-maximal effective concentration: 16 nM
The estimate for compound 3 lay 1.1-fold (0.03 log units) below the measured number; low and high end bracket the measured number.
By their numbers in this assay, from the lowest: compound 1; then compound 3; then compound 2.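

The ether side chain is a place where the series responds: in this assay the change from 2-chlorobenzyl to 2-(1H-pyrazol-1-yl)ethyl gives an 8.0-fold higher number from compound 1 to compound 3 (0.90 log units; beyond the scatter) on this position. Even so, compound 3 gives 16 nM with a five-membered aromatic ring with 2 hetero atoms on the chain, so a chlorine-bearing ring of carbon only is not required for a number of this order. Nothing available here accounts for the size of this step.

The ring and the chain length change together in this one step, so their shares cannot be separated. The compounds shown leave open how a plain benzyl without chlorine, a 2-phenylethyl chain carrying the carbon ring at the pyrazole's distance, or an amine at the end of the chain would read.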